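Chloro-hydroxyphenyl in place of bromophenyl on the dienone core

The source may report more compounds than this note shows. Statements on the series, on what has been measured and on what is new or still open speak of the compounds shown alone.

Measured compounds:
compound 1, `COc1cccc(/C=C2\CCC/C(=C\c3ccc(Cl)cc3)C2=O)c1OC`, 11100 nM
compound 2, `COc1cccc(/C=C2\CCC/C(=C\c3cc(Cl)cc(Cl)c3)C2=O)c1OC`, 5500 nM
compound 3, `COc1ccc(/C=C2\CCC/C(=C\c3ccccc3Br)C2=O)cc1OC`, 5300 nM

In a functional assay on SW-620 cells (Homo sapiens) for cytotoxicity, read by MTT assay, with a stated time of 72 h (on this read-out higher numbers stand for weaker inhibition and lower numbers for stronger inhibition), compound 3 gives 5300 nM, which lies within the scatter of compound 2 and beyond the scatter of compound 1. Compound 4, `COc1ccc(/C=C2\CCC/C(=C\c3ccc(O)c(Cl)c3)C2=O)cc1OC`, carries 3-chloro-4-hydroxyphenyl in place of 2-bromophenyl on a double-bonded chain carbon bound to a double-bonded ring carbon. Going by the values given here, the only measured step on this position is a 2.0-fold lower number from compound 1 to compound 2 (0.30 log units; within the scatter), an exchange of one chloro-substituted phenyl for another that stayed within the scatter. Among the compounds with values here, no step exchanges a halogen-only phenyl for one bearing a hydroxyl, so the data give no direction for such a change. Compound 4 is therefore expected to sit close to compound 3, with an estimated step of a 1.0-fold higher number from compound 3 to compound 4 (0.02 log units; within the scatter). The estimate for compound 4 is 5500 nM, within 2000 nM to 16000 nM.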

Compound 4, half-maximal inhibitory concentration: 7100 nM
The estimate for compound 4 lay 1.3-fold (0.11 log units) below the measured number; the range from low to high includes it.
By their numbers in this assay, from the lowest: compounds 3, 2, 4 and 1 (each within the scatter of the next, the first and the last beyond it).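

In this assay, the exchange of 2-bromophenyl for 3-chloro-4-hydroxyphenyl gives a 1.3-fold higher number from compound 3 to compound 4 (0.13 log units; within the scatter), the only step shown that brings a hydroxyl onto this phenyl. On a double-bonded chain carbon bound to a double-bonded ring carbon, then, a phenyl with a hydrogen-bond donor and acceptor stays within the scatter of one with neither. No independent measurement bears on this result. The compounds shown leave open what the hydroxyl contributes alone, as the halogen changes in the same step. They also leave open whether an amine or a carboxylic acid here would stay within the scatter.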